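Swapping the end group on the compound 2 side chain

The compounds below may be only part of what the source reports. "The series", "measured", "known", "first", "only" and "open" are said of these compounds alone.

Compound 1 `COc1ncc(-c2ccc3nc(NC(=O)N4CCCC4)nn3c2)cc1NS(=O)(=O)c1ccc(F)cc1` gives 3570 nM
Compound 2 `COc1ncc(-c2ccc3nc(NC(=O)NCCN4CCCCC4)nn3c2)cc1NS(=O)(=O)c1ccc(F)cc1` gives 610 nM

Both values come from a functional assay on A549 cells (Homo sapiens) for cytotoxicity, read by MTT assay, with a stated time of 72 h (on this read-out lower numbers stand for stronger inhibition and higher numbers for weaker inhibition), and compound 2 has the lower number of the two. Compound 3 `COc1ncc(-c2ccc3nc(NC(=O)NCCN(C)C)nn3c2)cc1NS(=O)(=O)c1ccc(F)cc1` has not yet been measured. It differs from compound 2 by a single change, dimethylamino in place of piperidin-1-yl on a saturated chain carbon, two bonds along the chain from an amide-type nitrogen. Going by the values given here, only one measured step bears on this change, namely a 5.9-fold lower number from compound 1 to compound 2 (0.77 log units; beyond the scatter) and it is modest but beyond the scatter. That step replaced pyrrolidin-1-yl on a carbonyl carbon with (2-(piperidin-1-yl)ethyl)amino. Compound 3 keeps the 2-substituted ethyl chain and changes only the group at its end. Among the compounds with values here, no measured pair compares these two end groups directly, so the evidence is thin. A smaller change than that earlier step is expected, leaning slightly towards a higher number and probably staying within the scatter. The expected step is a 1.5-fold higher number from compound 2 to compound 3 (0.17 log units; within the scatter) in this estimate. For compound 3 the estimated value is 900 nM with an expected range of 300 nM to 2500 nM in this assay as the read-out.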

Compound 3, half-maximal inhibitory concentration: 800 nM
Estimate against measurement, compound 3: 1.1-fold (0.05 log units) above, within the range that was stated.
By their numbers in this assay, from the lowest: compounds 2 and 3 (each within the scatter of the next); then compound 1.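

In this assay, the end of the 2-substituted ethyl chain can change from piperidin-1-yl, a six-membered ring of 6 heavy atoms, to dimethylamino, which has 3 heavy atoms and no ring, with a step that stays within the scatter: a 1.3-fold higher number from compound 2 to compound 3 (0.12 log units; within the scatter). The chain with this smaller end group also keeps a difference from the pyrrolidin-1-yl urea that lies beyond the scatter, a 4.5-fold lower number from compound 1 to compound 3 (0.65 log units; beyond the scatter), so at least in compound 3 the ring at the end of the chain is not required for that difference. Nothing measured here gives a reason why these end groups read alike.

The compounds shown leave open whether the nitrogen at the end of the chain matters at all, which a chain ending in a hydroxyl group or a methoxy group could test, and whether an end ring with a second hetero atom, such as morpholin-4-yl, would fit the same picture. They also leave open how the numbers respond to a longer chain, such as a 3-(dimethylamino)propyl group in place of the 2-(dimethylamino)ethyl group.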